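The source may report more compounds than this note shows. Statements on the series, on what has been measured and on what is new or still open speak of the compounds shown alone.

In an ADME assay on Huh-7 cells (Homo sapiens) for cytotoxicity (on this read-out lower numbers stand for higher toxicity in this test and higher numbers for lower toxicity in this test), compound 1 `NC(=S)Nc1cccc(OCCCCCN2CCN(c3ccc(C4CCCCC4)cc3)C2=O)c1` gives 12000 nM. Compound 2 `NC(=S)Nc1cccc(OCCCCCCCCNC(=S)Nc2ccccc2)c1` reaches only a limit of the test, > 50000 nM. This is the limit of > 50000 nM in this assay, at which 1 of the 2 values shown sits, so where compound 2 truly stands is not a number. Compound 3 `NC(=S)Nc1cccc(OCCCCCCCCNC(=S)Nc2ccc3[nH]ccc3c2)c1` differs from compound 2 in one place: 1H-indol-5-yl in place of phenyl on an amide-type nitrogen. Within the data shown here, no measured pair shows this change. The expected step is therefore a number no higher from compound 2 to compound 3 (the limit leaves the size open), that is, none beyond the usual scatter. Compound 3 is estimated at 50000 nM, most likely between 20000 nM and 100000 nM, with a fair chance that the test again reports only a limit.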

Compound 3, half-maximal cytotoxic concentration: 18000 nM
The estimate for compound 3 lay 2.8-fold (0.44 log units) above the measured number; the whole stated range lies above it.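

In this assay, the group on the amide-type nitrogen proves able to move the read-out: 1H-indol-5-yl in place of phenyl gives an at least 2.7-fold lower number from compound 2 to compound 3 (0.44 log units; beyond the scatter). Among these compounds, this change goes towards higher toxicity in this test, which the earlier compounds could not show. The full size of the step stays unknown because compound 2 gives only a limit: the limit of > 50000 nM in this assay, at which 1 of the 3 values shown sits.

The compounds shown leave open whether the second ring or its nitrogen, with the hydrogen-bond donor counted there, accounts for the step. A naphthyl group, with two rings of carbon only, would separate the two.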